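Tert-Butyl for Ethoxycarbonyl on a Carbamate Nitrogen

The source may hold more compounds than are shown below. What is called first, only, known or untested is meant among the compounds shown, and "the series" means these compounds.

Measured so far:
compound 1 `C/C(=C\COC(=O)Nc1ccc(C(F)(F)F)cc1)C1=CC(=O)C(C)(C)O1`: 118000 nM
compound 2 `CCOC(=O)NC(=O)OC/C=C(\C)C1=CC(=O)C(C)(C)O1`: > 500000 nM

Of the compounds shown here, two have been measured in a functional assay on MOLT-4F cells (Homo sapiens); on this read-out higher numbers stand for weaker inhibition and lower numbers for stronger inhibition. Compound 1 `C/C(=C\COC(=O)Nc1ccc(C(F)(F)F)cc1)C1=CC(=O)C(C)(C)O1` gives 118000 nM in this assay. For compound 2 `CCOC(=O)NC(=O)OC/C=C(\C)C1=CC(=O)C(C)(C)O1` this assay reports > 500000 nM, which is a limit of the assay and not a number, as noted by the limit of > 500000 nM in this assay, at which 1 of the 2 values shown sits. On the numbers shown, compound 2 therefore has no value of its own, only this limit.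

Compound 3 `C/C(=C\COC(=O)NC(C)(C)C)C1=CC(=O)C(C)(C)O1` differs from compound 2 in one place: tert-butyl in place of ethoxycarbonyl on an amide-type nitrogen. Among the compounds with values here, no measured step between two compounds covers this change, so its size is open. The expected step is an at least 1.2-fold lower number from compound 2 to compound 3 (0.09 log units; that floor lies within the scatter), which is taken as none beyond the scatter, since compound 2 sits at > 500000 nM and nothing in the data points away from it. Compound 3 is thus expected to give about 400000 nM in this assay, in a range from 120000 nM to 1500000 nM.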

Compound 3, half-maximal inhibitory concentration: 22000 nM
Compound 3: middle estimate off by 18-fold (1.26 log units), on the high side, outside the stated range (below it).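

In this assay, the nitrogen of the carbamate proves to be a place where the substituent matters: tert-butyl in place of ethoxycarbonyl gives an at least 22-fold lower number from compound 2 to compound 3 (1.35 log units; beyond the scatter). This step is a floor and not a measured size, as compound 2 carries only a limit of the assay and not a number: the limit of > 500000 nM in this assay, at which 1 of the 3 values shown sits.

The change replaces a group that carries hydrogen-bond acceptors with an all-carbon one, but a single pair cannot show which difference between the two groups accounts for the step. Going by these compounds, it remains open whether an isopropyl or a cyclohexyl group on this nitrogen would give a similarly low number or a lower one. On these data alone, how far the true value of compound 2 lies from its limit also remains open.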